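Replacing the methoxycarbonyl-bearing ring of compound 2

The compounds below may be only part of what the source reports. "The series", "measured", "known", "first", "only" and "open" are said of these compounds alone.

Measured in a functional assay on HepG2 cells (Homo sapiens) for inhibition, read by MTT assay; a lower number here means a stronger inhibitor of growth, a higher number a weaker inhibitor of growth:
- Compound 1 `COc1cc2oc(-c3cccc(NC(=O)c4ccc(F)cc4)c3)cc(=O)c2c(OC)c1OC`: 47200 nM
- Compound 2 `COC(=O)c1ccc(C(=O)Nc2cccc(-c3cc(=O)c4c(OC)c(OC)c(OC)cc4o3)c2)cc1`: > 100000 nM

For compound 2, the reading of > 100000 nM is only a limit and not a number. Compound 3 `COc1cccc(C(=O)Nc2cccc(-c3cc(=O)c4c(OC)c(OC)c(OC)cc4o3)c2)c1` carries 3-methoxyphenyl in place of 4-(methoxycarbonyl)phenyl on a carbonyl carbon. Among the measured compounds shown here, one measured step bears on this change: an at least 2.1-fold higher number from compound 1 to compound 2 (0.32 log units; beyond the scatter), where methoxycarbonyl replaced fluoro on an aromatic carbon. Since compound 3 has no methoxycarbonyl, that step is expected to be partly undone in this assay, giving a modest move to a lower number. The expected step is an at least 1.6-fold lower number from compound 2 to compound 3 (0.22 log units; that floor lies within the scatter). The estimate for compound 3 is 60000 nM, with an expected range of 25000 nM to 100000 nM.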

Compound 3, concentration for 50% growth inhibition: 7060 nM
Beside the measured number, compound 3's estimate is 8.5-fold (0.93 log units) above it, outside the stated range (below it).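

Among the compounds shown here, on this carbonyl carbon, the choice of aromatic group moves the result in this assay much further than the earlier compounds showed, with an at least 14-fold lower number from compound 2 to compound 3 (1.15 log units; beyond the scatter). The gain is not only against a limit: 3-methoxyphenyl also outperforms 4-fluorophenyl, with a 6.7-fold lower number from compound 1 to compound 3 (0.83 log units; beyond the scatter). The first step gives only a floor, since the reading for compound 2 is a limit and not a number: the limit of > 100000 nM in this assay, at which 1 of the 3 values shown sits.

Compound 3 differs from compound 1 and compound 2 in both the substituent and its place on the ring, and these compounds cannot separate the two changes. From the compounds shown here alone, whether 4-methoxyphenyl or 3-aminophenyl would match 3-methoxyphenyl remains open.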